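From methyl to methoxy: compound 3 to compound 4

A few compounds are considered here, and "the series" means these few. Any claim that something is new, unique, unknown or untested is made for them only; others in the source may bear on it.

compound 1 `Nc1ccc(S(=O)(=O)Nc2cccc3c(Cl)c[nH]c23)cc1` gives 10 ug/mL
compound 2 `Nc1ccc(S(=O)(=O)Nc2ccc(Br)c3c(Cl)c[nH]c23)cc1` gives 13 ug/mL
compound 3 `Cc1ccc(NS(=O)(=O)c2ccc(N)cc2)c2[nH]cc(Cl)c12` gives 16 ug/mL

These three values come from a functional assay on KB cells (Homo sapiens) for antiproliferative activity, read by colorimetric assay and MTT assay (a higher number here means a weaker inhibitor, a lower number a stronger inhibitor), and lie close together. Compound 3 stands within the scatter of both others, with a 1.6-fold higher number from compound 1 to compound 3 (0.20 log units; within the scatter) and a 1.2-fold higher number from compound 2 to compound 3 (0.09 log units; within the scatter) as its two steps. Compound 4 `COc1ccc(NS(=O)(=O)c2ccc(N)cc2)c2[nH]cc(Cl)c12` carries methoxy in place of methyl on an aromatic carbon on the same shared core. Among the measured compounds shown here, no measured step covers methoxy directly. The nearest evidence is the substituent swaps at this carbon: a 1.3-fold higher number from compound 1 to compound 2 (0.11 log units; within the scatter) for bromo, a 1.6-fold higher number from compound 1 to compound 3 (0.20 log units; within the scatter) for methyl, and a 1.2-fold higher number from compound 2 to compound 3 (0.09 log units; within the scatter) for methyl in place of bromo. None of these leaves the scatter, so no step beyond the scatter is expected here, in either direction. The expected change is a 1.1-fold lower number from compound 3 to compound 4 (0.06 log units; within the scatter) and would be too small to read as a real difference. Compound 4 is estimated at 14 ug/mL, with an expected range from 8 ug/mL to 25 ug/mL by this estimate.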

Compound 4, half-maximal inhibitory concentration: 20 ug/mL
For compound 4 the middle estimate is 1.4-fold (0.15 log units) below the measured one; the range from low to high includes it.
By their numbers in this assay, from the lowest: compounds 1, 2, 3 and 4 (each within the scatter of the next).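

In this assay, methoxy on this aromatic carbon, para to a large group, behaves like the substituents before it, with a 1.3-fold higher number from compound 3 to compound 4 (0.10 log units; within the scatter) for methoxy in place of methyl and a 1.5-fold higher number from compound 2 to compound 4 (0.19 log units; within the scatter) for methoxy in place of bromo. The largest step now seen at this carbon, a 2.0-fold higher number from compound 1 to compound 4 (0.30 log units; within the scatter) for methoxy in place of hydrogen, also stays within the scatter, so a group carrying a hydrogen-bond acceptor gives no readable difference from hydrogen, bromo or methyl here. No measurement in hand offers an explanation for how closely these four compounds sit.

From the compounds shown here alone, whether an amine, a carboxylic acid or a longer chain on this carbon would give a step beyond the scatter remains open. The compounds shown vary only this carbon, so it is also open whether changes elsewhere on the shared core would shift the number further.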